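A few compounds are considered here, and "the series" means these few. Any claim that something is new, unique, unknown or untested is made for them only; others in the source may bear on it.

Working notes on the series in an assay for inhibition of Indoleamine 2,3-dioxygenase 1 (Homo sapiens), with stated times of 10 min and 60 min, tested at 100 uM; a higher number here means a stronger effect of the compound at the concentration tested, a lower number a weaker effect. Compound 1 `Oc1ccc(CNc2cc(C(F)(F)F)cc3[nH]ncc23)c(Cl)c1` gives 95% in this assay. Compound 2 `N#Cc1cc(NCc2ccccc2[N+](=O)[O-])c2cn[nH]c2c1` gives 17% in this assay; this is the lower of the two numbers shown, and compound 1 stands above it by a gap well beyond the scatter. Compound 1 and compound 2 differ in more than one place, so nothing can be attributed to any single change between them. Compound 3 `O=[N+]([O-])c1ccccc1CNc1cc(C(F)(F)F)cc2[nH]ncc12` has not yet been measured in this assay. Against compound 2 the change is trifluoromethyl in place of cyano on an aromatic carbon. Within the data shown here, the only compound bearing trifluoromethyl at this place is compound 1 with its 95%, and that compound also carries a different group on the benzyl part, so its value gives a loose hint at most. A step upward is expected, of size a number 28 percentage points higher from compound 2 to compound 3 (beyond the scatter), with wide uncertainty. The estimate for compound 3 in this assay is 45%, within 15% to 80%.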

Compound 3, a percentage reported as inhibition, at one concentration (the size of the read-out at that concentration, not a potency): 76%
Compound 3: the middle estimate sits 31 percentage points below what was measured; the range from low to high includes it.
By their numbers in this assay, from the lowest: compound 2; then compound 3; then compound 1.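

In this assay the exchange of cyano for trifluoromethyl on this aromatic carbon of the shared core gives a number 59 percentage points higher from compound 2 to compound 3 (beyond the scatter) with the nitro-bearing benzyl part held fixed. Among these compounds, this is the first reading of the change on its own, and it shows that the group at this position strongly affects the percentage inhibition at the tested concentration. Nothing available bears on the reason for the step.

On these data alone, the step rests on a single pair, so it remains open whether trifluoromethyl would give a similar gain with the chloro- and hydroxy-bearing benzyl part of compound 1. As far as these compounds go, it is also open how other groups at this position, such as an amine, a carboxylic acid or a methoxy group, would compare with cyano and trifluoromethyl.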